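This account rests on a few compounds, and the source may have more. Where it says the series, first, only, none or still open, it means among the compounds named here.

Compound 1 `COc1ccc(S(=O)(=O)NCCN2CCC(CCC(=O)c3cc(Cl)c(N)cc3OC)CC2)cc1Br`: "not active" (no number reported)
Compound 2 `COc1ccc(S(=O)(=O)NCCN2CCC(CCC(=O)c3cc(Cl)c(N)cc3OC)CC2)cc1OC`: 3%

In an assay on HEK293 cells for displacement of a labelled ligand from 5-hydroxytryptamine receptor 6 (Homo sapiens), with a stated time of 60 min, tested at 0.01 uM, in the presence of a further agent that is not named here (on this read-out higher numbers stand for a stronger effect at the one concentration tested and lower numbers for a weaker effect), compound 1 is reported as "not active" (no number reported), with no number given. Within the data shown here, compound 2 gives 3% in this assay, the only number among the two measured compounds. Compound 3 `COc1cc(N)c(Cl)cc1C(=O)CCC1CCN(CCNS(=O)(=O)c2ccc(NC(C)=O)cc2)CC1` carries the change (4-acetamidophenyl in place of 3,4-dimethoxyphenyl on a sulfonyl sulfur). Among the measured compounds shown here, no step between measured compounds is known, so no expected size can be taken from the data; since compound 2 shows 3%, the step of a number 2 percentage points higher from compound 2 to compound 3 (within the scatter) is expected to stay within the scatter, in neither direction. Compound 3 is expected to give about 5%, between 0% and 18%.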

Compound 3, a percentage reported as inhibition, at one concentration (the size of the read-out at that concentration, not a potency): 7%
Beside the measured number, compound 3's estimate is 2 percentage points below it; measured number inside the range.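

In this assay, among these compounds, replacing 3,4-dimethoxyphenyl with 4-acetamidophenyl on a sulfonyl sulfur gives the first readable step at this position, a number 4 percentage points higher from compound 2 to compound 3 (within the scatter). The two groups therefore cannot be told apart here, even though the new one brings in an amide hydrogen. No measured evidence bears on this result.

As far as these compounds go, it remains open whether a different group on the sulfonyl sulfur, such as an amine or a carboxylic acid, would produce a step beyond the scatter. A single tested concentration also leaves the potency of these compounds unknown.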